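This account rests on a few compounds, and the source may have more. Where it says the series, first, only, none or still open, it means among the compounds named here.

Measured compounds:
- Compound 1, `CCOC(=O)C1=Cc2ccccc2OC1(OCc1cn(CC(=O)Nc2cccc(Cl)c2)nn1)C(F)(F)F`: in a functional assay on MCF7 cells (Homo sapiens) for inhibition, read by MTT assay, with a stated time of 24 h (on this read-out higher numbers stand for weaker inhibition and lower numbers for stronger inhibition), compound 1 gives 11600 nM.
- Compound 2, `CCOC(=O)C1=Cc2ccccc2OC1(OCc1cn(CC(=O)Nc2ccc(OC)cc2)nn1)C(F)(F)F`: in this assay compound 2 gives 28100 nM.
- Compound 3, `CCOC(=O)C1=Cc2ccccc2OC1(OCc1cn(CC(=O)Nc2ccccc2Br)nn1)C(F)(F)F`: in this assay compound 3 gives > 150000 nM, which is a limit of the assay and not a number.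

Compound 3 stands at the weak end of the three: the steps of an at least 12-fold higher number from compound 1 to compound 3 (1.11 log units; beyond the scatter) and an at least 5.3-fold higher number from compound 2 to compound 3 (0.72 log units; beyond the scatter) both run beyond the scatter, and only the limit is known for it (the limit of > 150000 nM in this assay, at which 1 of the 3 values shown sits). The remaining step, a 2.4-fold higher number from compound 1 to compound 2 (0.38 log units; beyond the scatter), is modest. Compound 4, `CCOC(=O)C1=Cc2ccccc2OC1(OCc1cn(CC(=O)Nc2ccc(I)cc2Cl)nn1)C(F)(F)F`, has not been measured; it differs from compound 3 by 2-chloro-4-iodophenyl in place of 2-bromophenyl on an amide-type nitrogen. Both measured steps onto compound 3 point towards weaker inhibition once the aryl group carries a substituent of this kind on the position named in 2-bromophenyl, and compound 4 keeps a halogen at the corresponding position of 2-chloro-4-iodophenyl. The step of an at least 1.5-fold lower number from compound 3 to compound 4 (0.17 log units; that floor lies within the scatter) is therefore expected to stay within the scatter, with a fair chance that only a limit is reported again. Compound 4 is estimated at 100000 nM in this assay, within 20000 nM to 400000 nM.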

Compound 4, half-maximal inhibitory concentration: 28100 nM
Beside the measured number, compound 4's estimate is 3.6-fold (0.55 log units) above it, within the range that was stated.
By their numbers in this assay, from the lowest: compound 1; then compounds 2 and 4 (each within the scatter of the next). At a limit, above all of these: compound 3.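

In this assay, 2-chloro-4-iodophenyl in place of 2-bromophenyl on the amide-type nitrogen gives an at least 5.3-fold lower number from compound 3 to compound 4 (0.72 log units; beyond the scatter), so a halogen on the aryl group does not by itself carry the loss of inhibition seen with 2-bromophenyl. The other two steps read no change at the digits printed from compound 2 to compound 4 (within the scatter) and a 2.4-fold higher number from compound 1 to compound 4 (0.38 log units; beyond the scatter), so 2-chloro-4-iodophenyl shows no separation from 4-methoxyphenyl and stays short of 3-chlorophenyl. The first of these steps gives only a floor, as the value of compound 3 is a limit and not a number: the limit of > 150000 nM in this assay, at which 1 of the 4 values shown sits.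

Whether the chlorine or the iodine of 2-chloro-4-iodophenyl accounts for the measurable value stays open, with neither 2-chlorophenyl nor 4-iodophenyl among the compounds shown. Also open, going by these compounds, is whether an amine or a carboxylic acid on the aryl group would give stronger inhibition than compound 1 does.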